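A few compounds are considered here, and "the series" means these few. Any claim that something is new, unique, unknown or untested is made for them only; others in the source may bear on it.

In a functional assay on VCaP cells (Homo sapiens) for antiproliferative activity, read by propidium iodide staining, with a stated time of 96 h (on this read-out higher numbers stand for weaker inhibition and lower numbers for stronger inhibition), compound 1 (`CC(O)(COc1ccc(S(F)(F)(F)(F)F)cc1)C(=O)Nc1cccc(S(F)(F)(F)(F)F)c1`) gives 8000 nM in the series, compound 2 (`CC(O)(COc1ccc(C(F)(F)F)cc1)C(=O)Nc1cccc(S(F)(F)(F)(F)F)c1`) gives 13300 nM and compound 3 (`CC(O)(COc1cccc(C(F)(F)F)c1)C(=O)Nc1cccc(S(F)(F)(F)(F)F)c1`) gives 22500 nM as the highest number of the three. Compound 3 lies within the scatter of compound 2, while the gap to the lower number of compound 1 goes beyond it. The next entry is compound 4 (`CC(O)(COc1ccc(C#N)cc1)C(=O)Nc1cccc(S(F)(F)(F)(F)F)c1`), with 4-cyanophenyl in place of 3-(trifluoromethyl)phenyl on an oxygen on a saturated carbon. For the measured compounds named here, two measured steps bear on this change. The step of a 1.7-fold higher number from compound 2 to compound 3 (0.23 log units; within the scatter) changes the same place, and the step of a 1.7-fold higher number from compound 1 to compound 2 (0.22 log units; within the scatter) exchanges one group on an aromatic carbon for another. Both stay within the scatter. No nitrile has been measured in the series, so the support is indirect. No step beyond the scatter is therefore expected in this assay. The expected step is a 1.5-fold lower number from compound 3 to compound 4 (0.18 log units; within the scatter) and would be no real change. For compound 4 the estimated value is 15000 nM (expected range 6000 nM to 40000 nM).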

Compound 4, half-maximal inhibitory concentration: 26600 nM
The estimate for compound 4 lay 1.8-fold (0.25 log units) below the measured number, and the stated range covers the measured number.
By their numbers in this assay, from the lowest: compounds 1, 2, 3 and 4 (each within the scatter of the next, the first and the last beyond it).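

In this assay, 4-cyanophenyl in place of 3-(trifluoromethyl)phenyl on the oxygen gives a 1.2-fold higher number from compound 3 to compound 4 (0.07 log units; within the scatter), so a ring carrying a nitrile and one hydrogen-bond acceptor reads no differently here from one carrying trifluoromethyl. Cyano in place of trifluoromethyl on an aromatic carbon gives a 2.0-fold higher number from compound 2 to compound 4 (0.30 log units; within the scatter), also within the scatter, while cyano in place of pentafluorosulfanyl gives a 3.3-fold higher number from compound 1 to compound 4 (0.52 log units; beyond the scatter), the first single-place step in the series to pass beyond the scatter, and only modestly. Nothing available explains the size of any of these steps.

On these data alone, whether an amine or a carboxylic acid on this aromatic ring would shift the number further remains open. So does the effect of a saturated ring or a longer alkyl chain in place of the aromatic ring on the oxygen.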